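The source may hold more compounds than are shown below. What is called first, only, known or untested is meant among the compounds shown, and "the series" means these compounds.

Working notes on the dihydropyridine series.

Of the compounds shown here, two have been measured in a functional assay on the whole organism (strain Wistar) for inhibition, with Rattus norvegicus as the target, read by paw edema, with stated times of 30 min and 0.5 h, at a dose of 20 mg/kg; on this read-out lower numbers stand for less inhibition and higher numbers for more inhibition at the one dose given (going by the name of the read-out). Compound 1 `CCOC(=O)C1=C(C)NC(C)=C(C(=O)OCC)C1c1ccc(OCC(=O)Nc2c(C)cccc2C)cc1` gives 15.9%. Among the measured compounds shown here, compound 2 `CCOC(=O)C1=C(C)NC(C)=C(C(=O)OCC)C1c1ccc(OCC(=O)NNC(=O)c2cccs2)cc1` gives 44%, the higher of the two numbers, and the only measured step, a number 28.1 percentage points higher from compound 1 to compound 2 (beyond the scatter), lies beyond the scatter.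

Compound 3 `CCOC(=O)C1=C(C)NC(C)=C(C(=O)OCC)C1c1ccc(OCc2nnc(S)o2)cc1` is not yet measured in this assay . Its change from compound 2 is a group of 6 heavy atoms (2 carbon, 2 nitrogen, 1 oxygen, 1 sulfur; one five-membered aromatic ring with 3 hetero atoms) in place of a group of 11 heavy atoms (6 carbon, 2 nitrogen, 2 oxygen, 1 sulfur; one five-membered aromatic ring with 1 hetero atom), on a saturated chain carbon bound to an oxygen on an aromatic ring; the group of 11 heavy atoms leaves and the 5-sulfanyl-1,3,4-oxadiazol-2-yl enters on the saturated chain carbon bound to the oxygen on the aromatic ring. For the measured compounds named here, the one measured step replaced 2,6-dimethylphenyl with ((thiophen-2-yl)carbonyl)amino on an amide-type nitrogen; it does not touch the chain carbon and the amide-type nitrogen itself is removed in compound 3, so that step bears on the present change only loosely. The shared core and the aryl ether are kept. Going by the values given here, with only two numbers, the expected step of a number 14 percentage points lower from compound 2 to compound 3 (beyond the scatter) is set as a fall of moderate size, with wide uncertainty. Compound 3 is therefore expected to give about 30%, between 10% and 52%.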

Compound 3, a percentage reported as inhibition, in the whole organism at one dose (the size of the read-out at that dose, not a potency): 42.4%
The estimate for compound 3 lay 12.4 percentage points below the measured number, within the range that was stated.
By their numbers in this assay, from the lowest: compound 1; then compounds 3 and 2 (each within the scatter of the next).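

At the saturated chain carbon bound to an oxygen on an aromatic ring, the group of 11 heavy atoms can give way to the 5-sulfanyl-1,3,4-oxadiazol-2-yl of 6 heavy atoms without a change that can be read in this assay: the result is a number 1.6 percentage points lower from compound 2 to compound 3 (within the scatter). The earlier step altered only what sat on an amide-type nitrogen, whereas compound 3 lacks that nitrogen altogether, and the exchange for (2,6-dimethylphenyl)carbamoyl still gives a number 26.5 percentage points higher from compound 1 to compound 3 (beyond the scatter), so among these three compounds an amide-type nitrogen on the chain is not required for the higher numbers, and compound 1 stands alone at the low end. No available evidence bears on why two such different groups give numbers within the scatter of each other.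

From the compounds shown here alone, whether the sulfanyl on the oxadiazole ring contributes remains open, and a 5-amino-1,3,4-oxadiazol-2-yl or a carboxylic acid on the same chain carbon would test how much of this group the number depends on. All the numbers also come from a single dose, so whether compound 2 and compound 3 would stay level at other doses is unresolved.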